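Compound 3: replacing the aryl group of compound 2

The compounds below may be only part of what the source reports. "The series", "measured", "known", "first", "only" and "open" are said of these compounds alone.

In an ADME assay on HEK293 cells (Homo sapiens) for cytotoxicity, read by MTT assay, with a stated time of 72 h (on this read-out higher numbers stand for weaker inhibition and lower numbers for stronger inhibition), compound 1 `COc1ccc(C2=C(c3cc(OC)c(OC)c(OC)c3)C(=O)C(O[SiH2]C(C)(C)C)C2)cc1` gives > 100 ug/mL, which is a limit of the assay and not a number. Compound 2 `COc1ccc(C2=C(c3cc(OC)c(OC)c(OC)c3)C(=O)C(O[SiH2]C(C)(C)C)C2)cc1OC(C)C` gives > 100 ug/mL, again only a limit. The series therefore stands at the limit of > 100 ug/mL in this assay, at which 2 of the 2 values shown sit, and compound 2 has no measured number to build on.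

Compound 3 `COc1cc(C2=C(c3ccc(SC)cc3)CC(O[SiH2]C(C)(C)C)C2=O)cc(OC)c1OC` carries 4-(methylsulfanyl)phenyl in place of 3-isopropoxy-4-methoxyphenyl on a double-bonded ring carbon. Within the data shown here, one measured step bears on this aryl group: a step that the two limits leave unreadable from compound 1 to compound 2, with isopropoxy in place of hydrogen on an aromatic carbon. Among the measured compounds shown here, it gives no usable size, and no measured step covers the exchange of this whole group.

With nothing to carry over, no step beyond the usual scatter is expected in this assay, and no direction can be assigned. The expected step is a number no higher from compound 2 to compound 3 (the limit leaves the size open). A further limit is the likeliest report, although a measurable number cannot be excluded. For compound 3 the estimate is 100 ug/mL, with an expected range from 40 ug/mL to 200 ug/mL.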

Compound 3, half-maximal inhibitory concentration: > 100 ug/mL
Compound 3: no number, only a limit; the forecaster's own chance of this, stated with the estimate: 70%; the middle value lies on the limit itself.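

Compound 1, compound 2 and compound 3 all give a limit of the assay and not a number in this assay, so no step among them can be read: the limit of > 100 ug/mL in this assay, at which 3 of the 3 values shown sit.

The compounds shown leave open whether any change to the aryl groups on the shared core would bring a measurable number in this assay at all.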